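Methylamino in Place of Fluoro on a Shared Core

The source may report more compounds than this note shows. Statements on the series, on what has been measured and on what is new or still open speak of the compounds shown alone.

Of the compounds shown here, three built on one core have been tested in an ADME assay on cells (Homo sapiens) for cytotoxicity, read by polymerase chain reaction, with a stated time of 3 days; on this read-out higher numbers stand for lower toxicity in this test and lower numbers for higher toxicity in this test. Compound 1 `Nc1nc(Cl)c(-c2ccco2)c(N[C@@H]2C[C@H](CO)[C@@H](O)[C@H]2O)n1` gives a value that is a limit of the test, > 25000 nM. Compound 2 `Nc1nc(Cl)c(-c2cc3ccccc3s2)c(N[C@@H]2C[C@H](CO)[C@@H](O)[C@H]2O)n1` likewise reaches only a limit, > 25000 nM. Compound 3 `Nc1nc(Cl)c(-c2nc3ccc(F)cc3s2)c(N[C@@H]2C[C@H](CO)[C@@H](O)[C@H]2O)n1` stands at the same limit, > 25000 nM. Within the data shown here, the one measured step, a step that the two limits leave unreadable from compound 1 to compound 2, has limits at both of its ends and is not readable in size. Across the set, the only information in this assay is the limit itself: the limit of > 25000 nM in this assay, at which 3 of the 3 values shown sit.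

Compound 4 `CNc1ccc2nc(-c3c(Cl)nc(N)nc3N[C@@H]3C[C@H](CO)[C@@H](O)[C@H]3O)sc2c1` differs from compound 3 by methylamino in place of fluoro on an aromatic carbon. Among the measured compounds shown here, no measured step touches this change, and the one step that was measured cannot be read. Compound 4 is therefore expected to remain near the limit, with the step that the limit leaves unreadable from compound 3 to compound 4 expected to be no larger than the scatter. The estimate for compound 4 in this assay is 30000 nM, within a range of 10000 nM to 100000 nM.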

Compound 4, half-maximal cytotoxic concentration: 6000 nM
Beside the measured number, compound 4's estimate is 5.0-fold (0.70 log units) above it; measured number outside the range, below it.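

In this assay, among these compounds, methylamino in place of fluoro on an aromatic carbon gives an at least 4.1-fold lower number from compound 3 to compound 4 (0.61 log units; beyond the scatter), the only readable step in the set, and it shows that a change at this place on the shared core can move the read-out towards higher toxicity in this test. Compound 4 is the only compound shown whose value is a number, while the steps among the other compounds cannot be read: the limit of > 25000 nM in this assay, at which 3 of the 4 values shown sit. Compound 3 stands at a limit, so the full size of this step remains unknown.

The compounds shown leave open whether a plain amine, a dimethylamino group or a methoxy group at this place would lower the number in the same way. They also leave open what a longer chain on the methylamino nitrogen would do.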